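Bromo in place of acetyl at the cytotoxicity limit

The source may report more compounds than this note shows. Statements on the series, on what has been measured and on what is new or still open speak of the compounds shown alone.

Three measured compounds share one core. Compound 1 `CC(=O)c1cccc(-c2ccc(C(=O)N(Cc3cccc(OCCCCCC(=O)O)c3)C(C)C)cc2)c1` carries an acetyl on an aromatic carbon; compound 2 `CC(C)N(Cc1cccc(OCCCCCC(=O)O)c1)C(=O)c1ccc(-c2cccc(O)c2)cc1` carries a hydroxy in place of that acetyl, and compound 3 `CCOC(=O)CCCCCOc1cccc(CN(C(=O)c2ccc(-c3cccc(C(C)=O)c3)cc2)C(C)C)c1` carries ethyl in place of hydrogen on an oxygen next to a carbonyl group. In an ADME assay on HEK293 cells (Homo sapiens) for cytotoxicity, read by CellTiter-Glo and resazurin assay, with a stated time of 72 h (a higher number here means that more compound is needed for the effect, a lower number that less compound is needed), compound 1 gives > 26000 nM, a limit of the assay rather than a number. Compound 2 gives > 26000 nM, again a limit. Compound 3 likewise gives > 26000 nM, also a limit. Hence the step that the two limits leave unreadable from compound 1 to compound 2 and the step that the two limits leave unreadable from compound 1 to compound 3 cannot be read in size, and compound 3 stands where every value shown stands, at the limit of > 26000 nM in this assay, at which 3 of the 3 values shown sit. Compound 4 `CCOC(=O)CCCCCOc1cccc(CN(C(=O)c2ccc(-c3cccc(Br)c3)cc2)C(C)C)c1` differs from compound 3 in one place: bromo in place of acetyl on an aromatic carbon. Among the compounds with values here, no measured step speaks to the size of this change, since both steps are unreadable and all three values rest at the limit. Compound 4 is expected to give 30000 nM, with a range from 15000 nM to 80000 nM, most likely again reported as a limit. The step that the limit leaves unreadable from compound 3 to compound 4 that this estimate means is expected to be nothing readable beyond the scatter.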

Compound 4, half-maximal effective concentration: > 26000 nM
Compound 4: only a limit was reported (the forecaster's own chance of this, stated with the estimate: 85%); the middle value is on the limit's open side.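

The step from compound 3 to compound 4 cannot be read in size in this assay and both compounds rest at a limit, like every value shown: the limit of > 26000 nM in this assay, at which 4 of the 4 values shown sit.

The compounds shown leave open whether bromo, acetyl, hydroxy or the ethyl group changes this cytotoxicity at all.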